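Series notes: bromo added to compound 3

This account rests on a few compounds, and the source may have more. Where it says the series, first, only, none or still open, it means among the compounds named here.

Compound 1 `O=C(Nc1ccc(Oc2ccc(-c3nccs3)cc2)cc1)Nc1cccc(C(F)(F)F)c1` gives 71.5% in a functional assay on A549 cells (Homo sapiens) for inhibition, read by MTT assay and WST assay, with a stated time of 72 h, tested at 10 uM; on this read-out higher numbers stand for more inhibition of growth at the one concentration tested and lower numbers for less inhibition of growth. Compound 2 `Cc1ccc(NC(=O)Nc2ccc(Oc3ccc(-c4nccs4)cc3)cc2)cc1` gives 15.6% in this assay, and compound 3 `O=C(Nc1ccc(Oc2ccc(-c3ncc[nH]3)cc2)cc1)Nc1cccc(C(F)(F)F)c1` gives 30%. Both measured steps are large: a number 55.9 percentage points lower from compound 1 to compound 2 (beyond the scatter), with 4-methylphenyl in place of 3-(trifluoromethyl)phenyl on an amide-type nitrogen, and a number 41.5 percentage points lower from compound 1 to compound 3 (beyond the scatter), with 1H-imidazol-2-yl in place of 1,3-thiazol-2-yl on an aromatic carbon. Compound 3 thus stands second of the three numbers, beyond the scatter below compound 1 and beyond the scatter above compound 2.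

Compound 4 `O=C(Nc1ccc(Oc2ccc(-c3ncc[nH]3)cc2)cc1)Nc1cc(Br)cc(C(F)(F)F)c1` differs from compound 3 by bromo in place of hydrogen on an aromatic carbon, on an aromatic carbon of a six-membered aromatic ring of carbon only, meta to a trifluoromethyl group. Within the data shown here, neither measured step concerns an entering bromo; each changes a different part of the molecule, so no measured step bears on this change directly. The expected step in this assay is therefore a number 2 percentage points higher from compound 3 to compound 4 (within the scatter), small, with no direction supported by the data. Compound 4 is estimated at 32%, with a range from 14% to 52%.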

Compound 4, percent growth inhibition at one concentration: 44.1%
For compound 4 the middle estimate is 12.1 percentage points below the measured one; the measured number falls inside the stated range.
By their numbers in this assay, from the lowest: compound 2; then compound 3; then compound 4; then compound 1.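

In this assay, among these compounds, going from 3-(trifluoromethyl)phenyl to 3-bromo-5-(trifluoromethyl)phenyl gives a number 14.1 percentage points higher from compound 3 to compound 4 (beyond the scatter) and is the first measured change on this aryl group that keeps the trifluoromethyl group in place. The step shows that this aromatic carbon accepts a bromo, with growth inhibition rising rather than falling in the 1H-imidazol-2-yl compounds. Nothing available explains why the number rises.

Still open, going by these compounds, is whether bromo at this place gives a comparable step with 1,3-thiazol-2-yl in place of 1H-imidazol-2-yl, as in compound 1. Also open, on these data alone, is whether the step is particular to bromo or would also appear with another entering group, such as chloro, methoxy, an amine or a carboxylic acid.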